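Carboxy to Aminocarbamoyl: an Expected Step for Compound 3

The compounds below may be only part of what the source reports. "The series", "measured", "known", "first", "only" and "open" are said of these compounds alone.

Measured so far:
compound 1 `O=C(O)COc1ccncc1-c1ccc2ccccc2c1` gives 16%
compound 2 `CNC(=O)/C=C/c1ccncc1-c1ccc2c(ccn2C)c1` gives 99%

Of the compounds shown here, two have been tested in an assay on a protein complex for inhibition of CDK8/Cyclin C (Homo sapiens), with a stated time of 1 h, tested at 10 uM; on this read-out higher numbers stand for more inhibition at the one concentration tested (going by the name of the read-out) and lower numbers for less inhibition. Compound 1 sits at the lower of the two numbers with 16%, while compound 2 reaches 99%, a gap well beyond the usual scatter. Among the measured compounds shown here, compound 2 differs from compound 1 in more than one place, so no single change can be read from that gap; the two values show only that the number for compound 1 is low and the number for compound 2 is high at the concentration tested.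

Compound 3 `NNC(=O)COc1ccncc1-c1ccc2ccccc2c1` has not yet been measured. It keeps the core of compound 1 and alters only the end of the side chain: aminoamino in place of hydroxy on a carbonyl carbon. For the measured compounds named here, no measured pair isolates this change, so its direction in this assay rests on expectation alone. A modest rise from the low number of compound 1 seems the most likely outcome, with a real chance of no change beyond the scatter. In this assay the expected step is a number 14 percentage points higher from compound 1 to compound 3 (beyond the scatter). Compound 3 is therefore estimated at 30%, within a range from 5% to 65%.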

Compound 3, a percentage reported as inhibition, at one concentration (the size of the read-out at that concentration, not a potency): 19%
Estimate against measurement, compound 3: 11 percentage points above; the range from low to high includes it.
By their numbers in this assay, from the lowest: compounds 1 and 3 (each within the scatter of the next); then compound 2.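

In this assay, aminoamino in place of hydroxy on a carbonyl carbon gives a number 3 percentage points higher from compound 1 to compound 3 (within the scatter). Among the compounds shown here, this is the first pair that differs in one place, and it shows that the change from carboxy to aminocarbamoyl, at the end of the side chain on the core of compound 1, leaves the read-out within the scatter, even though the two groups differ in their heavy atoms and in their counts of hydrogen-bond donors and acceptors. No measurement available here offers an explanation for the two compounds reading alike.

This single exchange does not show whether other groups at the end of the side chain, such as an amine or a longer chain, would give a different number on this core. Going by these compounds, compound 2, at 99%, differs from compound 1 and compound 3 in more than one place, so it remains open which of its differences goes with its number in this assay.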